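A Methyl Added to Compound 3

The source may hold more compounds than are shown below. What is called first, only, known or untested is meant among the compounds shown, and "the series" means these compounds.

Compound 1 `Cc1cc(C(O)CCCCCO)ccc1-c1ccc(F)cc1F`: 1300 nM
Compound 2 `O=C(CCCCCO)c1ccc(-c2ccccc2)cc1`: 9000 nM
Compound 3 `O=C(CCCCCO)c1ccc(-c2ccc(F)cc2F)cc1`: 2000 nM

In a functional assay on cells (Osteoclast, Mus musculus) for cytotoxicity, read by resazurin assay (a higher number here means a weaker inhibitor, a lower number a stronger inhibitor), compound 3 cannot be told apart from compound 1, while compound 2 has a clearly higher number. Compound 4 `Cc1cc(C(=O)CCCCCO)ccc1-c1ccc(F)cc1F` differs from compound 3 by one change, methyl in place of hydrogen on an aromatic carbon. Among the measured compounds shown here, no measured pair shows this change alone. Compound 1 carries the same methyl and gives 1300 nM here, but it has an alcohol where compound 3 has a carbonyl. A small move to a lower number in this assay is therefore expected, or none beyond the scatter. The expected change is a 1.3-fold lower number from compound 3 to compound 4 (0.12 log units; within the scatter) and stays within the scatter. Compound 4 is estimated at 1500 nM with 600 nM to 3500 nM as its expected range.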

Compound 4, half-maximal inhibitory concentration: 1500 nM
Estimate against measurement, compound 4: no gap at the digits printed; low and high end bracket the measured number.
By their numbers in this assay, from the lowest: compounds 1, 4 and 3 (each within the scatter of the next); then compound 2.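

Among the compounds shown here, compound 3 and compound 4 are the one pair here that isolates methyl in place of hydrogen on an aromatic carbon, and in this assay this gives a 1.3-fold lower number from compound 3 to compound 4 (0.12 log units; within the scatter). So with the carbonyl in place, a methyl at this position, ortho to a group of 8 heavy atoms, leaves the two compounds indistinguishable in this cell assay. Nothing available here bears on the reason for this result.

Still open, going by these compounds, is whether an ethyl group or a chlorine atom at this carbon would behave like the methyl. Also open, on these data alone, is whether a methyl on another carbon of this ring would do the same.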